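This account rests on a few compounds, and the source may have more. Where it says the series, first, only, none or still open, it means among the compounds named here.

Measured so far:
compound 1, `c1ccc(-c2nnn[nH]2)c(Nc2cccc3c2CCCC3)c1`: 5200 nM
compound 2, `O=C(Nc1sccc1C(=O)O)c1ccc(SC(F)(F)F)cc1`: > 30000 nM

In an assay on isolated protein for activation of potassium channel subfamily K member 2 (Homo sapiens), read by thallium flux (on this read-out higher numbers stand for an effect only at larger amounts of compound and lower numbers for an effect already at smaller amounts), compound 1 gives 5200 nM. For compound 2 only a limit of the assay is recorded in this assay, > 30000 nM, and no number is known for it. The two compounds share no common scaffold, so their pair is not read as a step. For the measured compounds named here, compound 2 stands at the limit of > 30000 nM in this assay, at which 1 of the 2 values shown sits, the weaker end of what has been measured; compound 1 is the only compound with a number.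

Compound 3 `O=C(Nc1sc(-c2ccccc2)cc1C(=O)O)c1ccc(SC(F)(F)F)cc1` differs from compound 2 by phenyl in place of hydrogen on an aromatic carbon. Going by the values given here, no step between measured compounds is available to calibrate this change, and the starting point itself is only a limit. The expected step from compound 2 to compound 3 in this assay is an at least 2.0-fold lower number from compound 2 to compound 3 (0.30 log units; that floor lies within the scatter), a move toward a measurable number that remains uncertain. Compound 3 is estimated at 15000 nM in this assay, between 3000 nM and 60000 nM, with a real chance that only a limit is again reported.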

Compound 3, half-maximal effective concentration: 22400 nM
For compound 3 the middle estimate is 1.5-fold (0.17 log units) below the measured one; the range from low to high includes it.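

Phenyl in place of hydrogen on the aromatic carbon next to the ring sulfur brings the series to a number in this assay, where compound 3 gives 22400 nM. The change reads as an at least 1.3-fold lower number from compound 2 to compound 3 (0.12 log units; that floor lies within the scatter); only this floor is known, so it does not establish a gain beyond the usual scatter. The value of compound 2 is a limit of the assay and not a number: the limit of > 30000 nM in this assay, at which 1 of the 3 values shown sits.

On these data alone, what a methyl group or an amine would do on this same carbon stays open, as does a phenyl carrying a further group such as chlorine. Also open, as far as these compounds go, is whether a primary amide could replace the carboxy group with the phenyl kept in place, and how either change would move the number.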